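Swapping a Tert-Butylphenyl Arm for Cyclohexylmethyl

The source may report more compounds than this note shows. Statements on the series, on what has been measured and on what is new or still open speak of the compounds shown alone.

Of the compounds shown here, three built on one shared core have been tested in an ADME assay for permeability, using PAMPA, with a stated time of 30 min, at pH 7.4; on this read-out lower numbers stand for lower permeability and higher numbers for higher permeability. Compound 1 `COc1ccc(F)cc1CNCCCNc1ccnc2cc(CCc3ccccc3)ccc12` carries a phenethyl group and gives 23 10^-6 cm/s. Compound 2 `COc1ccc(-c2ccc3c(NCCCNCc4cc(F)ccc4OC)ccnc3c2)cc1` carries a 4-methoxyphenyl group at the same place and gives 237 10^-6 cm/s. Compound 3 `COc1ccc(F)cc1CNCCCNc1ccnc2cc(-c3ccc(C(C)(C)C)cc3)ccc12` carries a 4-(tert-butyl)phenyl group and gives 237 10^-6 cm/s. Compound 3 thus stands level with compound 2, the pair sitting together at the top of the three values with no change at the digits printed from compound 2 to compound 3 (within the scatter), while compound 1 sits furthest away: a 10-fold higher number from compound 1 to compound 3 (1.01 log units; beyond the scatter).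

Compound 4 `COc1ccc(F)cc1CNCCCNc1ccnc2cc(CC3CCCCC3)ccc12` is the next compound to be measured. Its difference from compound 3 is cyclohexylmethyl in place of 4-(tert-butyl)phenyl on an aromatic carbon. Among the compounds with values here, the measured step that bears on this is the one from compound 1 to compound 3, where phenethyl gave way to 4-(tert-butyl)phenyl and the number rose strongly. Cyclohexylmethyl resembles the phenethyl of compound 1 more than the 4-(tert-butyl)phenyl of compound 3, since in both a single ring hangs from the core through a chain, so the step is expected to run partly back toward compound 1: a 5.3-fold lower number from compound 3 to compound 4 (0.72 log units; beyond the scatter). Compound 4 is therefore estimated at 45 10^-6 cm/s, with a likely range from 12 10^-6 cm/s to 150 10^-6 cm/s.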

Compound 4, apparent permeability in the ADME assay: 23 10^-6 cm/s
The estimate for compound 4 lay 2.0-fold (0.29 log units) above the measured number, within the range that was stated.
By their numbers in the ADME assay, from the lowest: compounds 1 and 4 (each within the scatter of the next); then compounds 2 and 3 (each within the scatter of the next).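

In the ADME assay the position now falls into two levels: phenethyl and cyclohexylmethyl, which both reach the shared core through a carbon chain, go together, with no change at the digits printed from compound 1 to compound 4 (within the scatter), while the two groups whose aromatic ring sits directly on the core stand apart, with a 10-fold lower number from compound 3 to compound 4 (1.01 log units; beyond the scatter) and a 10-fold lower number from compound 2 to compound 4 (1.01 log units; beyond the scatter). The ring at the end of the chain is aromatic in compound 1 and non-aromatic in compound 4, and on this read-out that swap shows no effect, so an aromatic ring alone does not bring the higher number. In a physicochemical assay for acid dissociation, compound 3 gives 9.47 and compound 4 gives 9.47, which is no change at the digits printed from compound 3 to compound 4 (within the scatter), so a change that moves one read-out strongly leaves this one untouched.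

Nothing shown here explains why the two levels differ. As far as these compounds go, it also stays open whether the chain link or the ring type sets the level, and where a cyclohexyl ring bonded straight to the core, or a longer chain ending in a phenyl ring, would fall.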